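The compounds below may be only part of what the source reports. "The series", "measured", "known", "first", "only" and "open" are said of these compounds alone.

In a functional assay on MCF7 cells (Homo sapiens) for cytotoxicity, read by MTT assay, with a stated time of 24 h (on this read-out lower numbers stand for stronger inhibition and higher numbers for weaker inhibition), compound 1 `CCNc1cc(-c2ccc(NC(=O)Nc3ccc(OC)cc3)cc2C)ccn1`, which carries methyl, gives 9950 nM, and compound 2 `CCNc1cc(-c2ccc(NC(=O)Nc3ccc(OC)cc3)cc2C(F)(F)F)ccn1`, which carries trifluoromethyl at the same place, gives 5740 nM. For the measured compounds named here, these two values lie within the scatter of each other, so compound 2 cannot be ranked against compound 1, the only other measured compound. The next compound, compound 3 `CCNc1cc(-c2ccc(NC(=O)Nc3ccc(OC)cc3)cc2OC)ccn1`, keeps the core of compound 2 but has methoxy in place of trifluoromethyl on an aromatic carbon, ortho to a 2-(ethylamino)pyridin-4-yl group and meta to a large group: methoxy in place of trifluoromethyl on an aromatic carbon. Going by the values given here, only one measured step bears on this place, a 1.7-fold lower number from compound 1 to compound 2 (0.24 log units; within the scatter), a change from methyl to trifluoromethyl that stays within the scatter. Among the compounds with values here, no measured compound yet carries methoxy there, so the data offer no direct reading of that group. On the strength of that single small step, no change beyond the scatter is expected in this assay, and no direction can be firmly assigned. Compound 3 is estimated at 7500 nM, with an expected range from 3300 nM to 17000 nM. The expected size of the change is a 1.3-fold higher number from compound 2 to compound 3 (0.12 log units; within the scatter).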

Compound 3, half-maximal inhibitory concentration: 17500 nM
For compound 3 the middle estimate is 2.3-fold (0.37 log units) below the measured one; the whole stated range lies below it.
By their numbers in this assay, from the lowest: compounds 2, 1 and 3 (each within the scatter of the next, the first and the last beyond it).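

In this assay, for the compounds shown here, this position now shows a step beyond the scatter for the first time: methoxy in place of trifluoromethyl on the aromatic carbon produces a 3.0-fold higher number from compound 2 to compound 3 (0.48 log units; beyond the scatter) and so a modest loss of inhibition, whereas the earlier change from methyl to trifluoromethyl stayed within the scatter. Methoxy in place of methyl produces a 1.8-fold higher number from compound 1 to compound 3 (0.25 log units; within the scatter) and stays within the scatter, so these two groups cannot be told apart here, and only trifluoromethyl and methoxy separate among the three groups tried at this place. Nothing given here accounts for the gap between trifluoromethyl and methoxy.

On these data alone, it remains open where a chlorine atom, a plain hydrogen or a longer ether such as ethoxy would fall at this position relative to trifluoromethyl and methoxy. As far as these compounds go, all three compounds also keep the rest of the shared core, including the 2-(ethylamino)pyridin-4-yl group, so it is also open whether the same gap would appear with a free amine or a longer chain in place of the ethylamino group.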